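The source may report more compounds than this note shows. Statements on the series, on what has been measured and on what is new or still open speak of the compounds shown alone.

Three compounds have been measured in a functional assay on SW1573 cells (Homo sapiens) for inhibition, read by sulforhodamine B assay, with a stated time of 48 h; on this read-out higher numbers stand for weaker inhibition of growth and lower numbers for stronger inhibition of growth:

Compound 1 `COC(=O)[C@@]1(C)CCC=C2[C@@H]1CC[C@@H](C)[C@]2(C)Cc1c[nH]c2c(C)cccc12`: 7800 nM
Compound 2 `COC(=O)[C@@]1(C)CCC=C2[C@@H]1CC[C@@H](C)[C@]2(C)Cc1c[nH]c2c(Br)cccc12`: 14000 nM
Compound 3 `COC(=O)[C@@]1(C)CC[C@@H]2C3=C1CC[C@@H](C)[C@]3(C)C[C@@H]1c3cc(C)ccc3N[C@H]21`: 23000 nM

Compounds 1 and 2 share one core and differ in a single place, (bromo in place of methyl on an aromatic carbon). That change made a step of a 1.8-fold higher number from compound 1 to compound 2 (0.25 log units; within the scatter). Compound 3 has the same atoms as compound 1, joined differently; the difference between the two cores is not broken down here. Its number is beyond the scatter from that of compound 1, while its number and that of compound 2 lie within the scatter of each other.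

Compound 4 `COC(=O)[C@@]1(C)CC[C@@H]2C3=C1CC[C@@H](C)[C@]3(C)C[C@@H]1c3cc(Br)ccc3N[C@H]21` has not yet been measured. It stands to compound 3 as compound 2 stands to compound 1: bromo in place of methyl on an aromatic carbon. The surroundings are not the same, since here the aromatic carbon is part of a fused or bridged system of five rings, meta to a fused ring and para to a fused ring, whereas in compound 1 it is part of a fused or bridged system of two rings, ortho to a fused ring and meta to a fused ring; so this is the same kind of change, not the same change. The expected step from compound 3 to compound 4 in this assay is a 1.5-fold higher number from compound 3 to compound 4 (0.18 log units; within the scatter), set beside the earlier one because compound 1 to compound 2 gave a 1.8-fold higher number from compound 1 to compound 2 (0.25 log units; within the scatter). Compound 4 is therefore estimated at 35000 nM, with a likely range from 15000 nM to 80000 nM.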

Compound 4, concentration for 50% growth inhibition: 45000 nM
Beside the measured number, compound 4's estimate is 1.3-fold (0.11 log units) below it; measured number inside the range.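

In this assay, bromo in place of methyl on an aromatic carbon of the core of compound 3 gave a 2.0-fold higher number from compound 3 to compound 4 (0.29 log units; within the scatter). Set beside the same change on the core of compound 1, the two steps agree: the same change on two cores in this assay, a 1.8-fold higher number (0.25 log units; within the scatter) from compound 1 to compound 2 and a 2.0-fold higher number (0.29 log units; within the scatter) from compound 3 to compound 4, 1.1-fold (0.04 log units) apart, within the scatter of two such steps. On these two cores and in this one assay, the change therefore carried over with no detectable difference in size, but each step lies within the scatter, so the data do not show that the bromo and methyl compounds of either pair truly differ, and two pairs establish no rule for other cores.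

The compounds shown leave open how other groups on this aromatic carbon, such as methoxy, an amine or a carboxylic acid, would read on either core, as only methyl and bromo appear there. Also open, going by these compounds, is how either core would read with a carboxylic acid or an amide in place of the methyl ester.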